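The source may report more compounds than this note shows. Statements on the series, on what has been measured and on what is new or still open speak of the compounds shown alone.

Compounds measured in an assay on a protein complex for binding affinity to Neuronal acetylcholine receptor; alpha4/beta2 (Rattus norvegicus) (on this read-out lower numbers stand for stronger inhibition and higher numbers for weaker inhibition), so far:

compound 1, `CCN1CCC(Oc2cccnc2)C1`, > 10000 nM (a limit of the assay)
compound 2, `CC(C)N1CCC(Oc2cccnc2)C1`, > 10000 nM (a limit of the assay)
compound 3, `C#Cc1cncc(O[C@@H]2CCNC2)c1`, 62 nM

Compound 1 gives only a limit in this assay, > 10000 nM. Compound 2 likewise gives only a limit, > 10000 nM. Going by the values given here, compound 3 is the one compound with a number, 62 nM, and it therefore stands alone as the reference point for anything built on its core. The step from compound 1 to compound 2 is a step that the two limits leave unreadable from compound 1 to compound 2, since both of its values sit at the limit of > 10000 nM in this assay, at which 2 of the 3 values shown sit.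

Compound 4, `C#Cc1cc(O[C@@H]2CCNC2)cnc1Cl`, differs from compound 3 in one place: chloro in place of hydrogen on an aromatic carbon. Among the compounds with values here, no measured step touches this change; the only measured step concerns methyl against hydrogen on the amine side of a different core, and it is unreadable in any case. The expectation for compound 4 therefore rests on the number for compound 3 alone, with no evidence for a move in either direction beyond the scatter. The step from compound 3 to compound 4 is estimated at a 1.3-fold higher number from compound 3 to compound 4 (0.11 log units; within the scatter). For compound 4 the estimated value in this assay is 80 nM, within a range from 20 nM to 400 nM.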

Compound 4, half-maximal inhibitory concentration: 46 nM
Beside the measured number, compound 4's estimate is 1.7-fold (0.24 log units) above it, within the range that was stated.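

In this assay, chloro in place of hydrogen on an aromatic carbon, next to the ring nitrogen and ortho to an ethynyl group, gives a 1.3-fold lower number from compound 3 to compound 4 (0.13 log units; within the scatter) and so leaves compound 3 and compound 4 indistinguishable on this read-out. This is the first step among the compounds shown that can be read, since the earlier step runs between two limits of the assay, and it shows that this place on the ring takes a chlorine atom while the compound still gives a measured number that cannot be told from the one without it. Nothing available offers a reason for this outcome.

The compounds shown leave open whether a different group at the same place, such as fluoro, bromo, methyl, an amine or a nitrile, would also stay within the scatter or would move the number clearly in one direction. They also leave open whether chloro would behave the same way at the other open carbons of the ring, or on a core that lacks the ethynyl group.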